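Swapping phenyl for pyridin-4-yl on a weak inhibitor

This account rests on a few compounds, and the source may have more. Where it says the series, first, only, none or still open, it means among the compounds named here.

Compound 1 `CC(C)(C)c1ccccc1Oc1ncccc1NC(=O)Nc1ccc(C(F)(F)F)cc1`: 12600 nM
Compound 2 `CC(C)(C)c1ccccc1Oc1ncccc1Nc1nnc(-c2ccccc2)s1`: 13000 nM

Of the compounds shown here, two have been measured so far in a functional assay on a cell-free system (Platelet, plasma, Homo sapiens) for inhibition; a higher number here means a weaker inhibitor, a lower number a stronger inhibitor. Compound 2 gives 13000 nM, and compound 1 gives 12600 nM. These two numbers lie within the scatter of each other, so compound 2 stands level with compound 1 and neither can be ranked above the other.

The two measured compounds differ in more than one place, so no single change has yet been tested. The next compound, compound 3 `CC(C)(C)c1ccccc1Oc1ncccc1Nc1nnc(-c2ccncc2)s1`, keeps the rest of compound 2 and carries pyridin-4-yl in place of phenyl on an aromatic carbon. The swap sits on the five-membered aromatic ring with 2 nitrogen and 1 sulfur.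

Among the measured compounds shown here, with no measured step to guide it, the forecast starts from compound 2 at 13000 nM. A change beyond the scatter is not expected in this assay, and the expected step is small, a 1.2-fold higher number from compound 2 to compound 3 (0.06 log units; within the scatter). For compound 3 the estimated value is 15000 nM, within an expected range of 5000 nM to 45000 nM.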

Compound 3, half-maximal inhibitory concentration: 29000 nM
The estimate for compound 3 lay 1.9-fold (0.29 log units) below the measured number; measured number inside the range.
By their numbers in this assay, from the lowest: compounds 1 and 2 (each within the scatter of the next); then compound 3.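

Among the compounds shown here, this is the first single change that can be read in this assay, and it shows that the group on this aromatic carbon, next to the ring nitrogen and next to the ring sulfur, is not indifferent: pyridin-4-yl in place of phenyl gives a 2.2-fold higher number from compound 2 to compound 3 (0.35 log units; beyond the scatter), a modest step towards weaker inhibition. The heavy-atom count stays the same, and the change puts a nitrogen into the six-membered aromatic ring and brings in a hydrogen-bond acceptor, so even this close replacement of phenyl registers in the assay. No measurement offered here bears on why the number rose.

On these data alone, with pyridin-4-yl the only replacement for phenyl in view, it remains open whether the step follows the presence of the ring nitrogen or its place in the ring, which pyridin-3-yl or pyridin-2-yl could separate. Also open, as far as these compounds go, is whether any other group here, such as a phenyl carrying an amine or a carboxylic acid, can bring the number down from compound 2 at 13000 nM.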